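Replacing Phenylsulfanyl with 4-Bromophenoxy on a Shared Core

A few compounds are considered here, and "the series" means these few. Any claim that something is new, unique, unknown or untested is made for them only; others in the source may bear on it.

Measured so far in a functional assay on A549 cells (Homo sapiens) for antiproliferative activity, read by MTT assay, with a stated time of 48 h; a higher number here means a weaker inhibitor, a lower number a stronger inhibitor:
Compound 1, `O=c1cc(-n2cc(CSc3ccccc3)nn2)c2cc(Br)ccc2o1`, gives 3510 nM.
Compound 2, `O=c1cc(-n2cc(COc3cccnc3)nn2)c2cc(Br)ccc2o1`, gives 24800 nM.
Compound 3, `O=c1cc(-n2cc(COc3ccccc3Br)nn2)c2cc(Br)ccc2o1`, gives 8430 nM.

Compound 1 stands lowest of the three, so it is the strongest inhibitor here: compound 3 is nearest, a 2.4-fold higher number from compound 1 to compound 3 (0.38 log units; beyond the scatter), and compound 2 is furthest, a 7.1-fold higher number from compound 1 to compound 2 (0.85 log units; beyond the scatter). Between the two oxygen-linked compounds, a 2.9-fold lower number from compound 2 to compound 3 (0.47 log units; beyond the scatter).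

The unmeasured compound 4, `O=c1cc(-n2cc(COc3ccc(Br)cc3)nn2)c2cc(Br)ccc2o1`, differs from compound 1 in one place: 4-bromophenoxy in place of phenylsulfanyl on a saturated chain carbon bound to an aromatic carbon. Within the data shown here, the step that bears most directly on it is the one from compound 1 to compound 3, where a bromine-carrying phenoxy group also took the place of phenylsulfanyl and the number rose modestly. The step from compound 1 to compound 2 shows that exchanging phenylsulfanyl for an oxygen-linked ring can cost more, but compound 2 carries a pyridin-3-yl ring rather than a bromophenyl ring, so compound 3 is the closer guide. For compound 4 a step about as large as that to compound 3 is expected, in the weaker direction, a 2.3-fold higher number from compound 1 to compound 4 (0.36 log units; beyond the scatter), and its value in this assay is estimated at 8000 nM, with a range from 3500 nM to 18000 nM.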

Compound 4, half-maximal inhibitory concentration: 24500 nM
For compound 4 the middle estimate is 3.1-fold (0.49 log units) below the measured one, and the stated range ends below it.
By their numbers in this assay, from the lowest: compound 1; then compound 3; then compounds 4 and 2 (each within the scatter of the next).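

Moving the bromine on the phenoxy ring changes the result in this assay: with 4-bromophenoxy in place of 2-bromophenoxy on the oxygen-linked side chain, the step is (a 2.9-fold higher number from compound 3 to compound 4 (0.46 log units; beyond the scatter)), so at this place the two bromophenoxy groups cannot be treated as interchangeable. A single result for one bromophenoxy group therefore did not settle what replacing phenylsulfanyl costs, since the 4-bromophenoxy exchange gives (a 7.0-fold higher number from compound 1 to compound 4 (0.84 log units; beyond the scatter)), which is a larger step than the one printed for the 2-bromophenoxy exchange (a 2.4-fold higher number from compound 1 to compound 3 (0.38 log units; beyond the scatter)). The assay also does not separate 4-bromophenyl from pyridin-3-yl on the oxygen (a 1.0-fold lower number from compound 2 to compound 4 (0.01 log units; within the scatter)), so among these oxygen-linked compounds, compound 3 alone stands apart from the other two.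

The compounds shown leave open whether 4-bromophenylsulfanyl would keep the number of compound 1 or follow the rise seen with 4-bromophenoxy, and how an amine in place of the linking oxygen would compare. Nothing measured here offers an explanation for these differences.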